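A few compounds are considered here, and "the series" means these few. Any claim that something is new, unique, unknown or untested is made for them only; others in the source may bear on it.

Compound 1 `Cc1cccc(Cn2cc(COc3ccc4c(=O)ccoc4c3)nn2)c1`: 16000 nM
Compound 2 `O=c1ccoc2cc(OCc3cn(Cc4ccccc4Cl)nn3)ccc12`: 15100 nM

Within the data shown here, in a functional assay on MDA-MB-231 cells (Homo sapiens) for cytotoxicity, read by MTT assay, with a stated time of 48 h (on this read-out higher numbers stand for weaker inhibition and lower numbers for stronger inhibition), compound 2 gives 15100 nM, the lowest of the two numbers measured so far, although its distance to compound 1 is small: a 1.1-fold lower number from compound 1 to compound 2 (0.03 log units; within the scatter), which is within the scatter. Compound 3 `O=c1ccoc2cc(OCc3cn(Cc4ccccc4)nn3)ccc12` differs from compound 2 by hydrogen in place of chloro on an aromatic carbon. Among the measured compounds shown here, only one measured step touches this part of the molecule, the swap of the group on the benzyl ring going from compound 1 to compound 2 a 1.1-fold lower number from compound 1 to compound 2 (0.03 log units; within the scatter), and it left the number essentially unchanged. For the measured compounds named here, no measured pair shows removal of a chloro group by itself, so there is no direct precedent, but the single step available suggests this ring tolerates variation without a shift beyond the scatter. The expected step is therefore small: a 1.1-fold higher number from compound 2 to compound 3 (0.05 log units; within the scatter). Compound 3 is estimated at 17000 nM, within a range of 8000 nM to 36000 nM.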

Compound 3, half-maximal inhibitory concentration: > 100000 nM
Compound 3 was reported as a limit; the forecaster's own chance of this, stated with the estimate: 15%; at least 5.8-fold (0.76 log units) between middle value and limit.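

The earlier pair suggested that this benzyl ring tolerates change, but that pair only swapped one group for another, and the bare ring behaves differently. Putting hydrogen in place of chloro gives an at least 6.6-fold higher number from compound 2 to compound 3 (0.82 log units; beyond the scatter), and putting hydrogen in place of methyl gives an at least 6.2-fold higher number from compound 1 to compound 3 (0.79 log units; beyond the scatter), so among these three compounds, the two with a group on the ring have measurable values in this assay and the one without has none. These steps give only a minimum size, since the value of compound 3 is a limit and not a number: the limit of > 100000 nM in this assay, at which 1 of the 3 values shown sits.

The chloro and the methyl do not sit at the same place on the ring, so the effect of the group cannot be separated from the effect of its place. Going by these compounds, whether an amine or a carboxylic acid on this ring would also give a measurable value remains open.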